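Benzyl exchange on the shared core: compound 1 to compound 4

The source may report more compounds than this note shows. Statements on the series, on what has been measured and on what is new or still open speak of the compounds shown alone.

Compound 1 `OC[C@H]1O[C@@H](n2cnc3c(NCc4ccc(Cl)cc4Cl)ncnc32)[C@H](O)[C@@H]1O` carries a 2,4-dichlorobenzyl group on the shared core. In a functional assay on HOS cells (Homo sapiens) for antiproliferative activity, with a stated time of 72 h (a higher number here means a weaker inhibitor, a lower number a stronger inhibitor), compound 1 gives only a limit, > 166000 nM. Compound 3 `COc1ccc(CNc2ncnc3c2ncn3C2OC(CO)[C@@H](O)[C@H]2O)c(O)c1` likewise gives only a limit in this assay, > 166000 nM. Compound 2 `OC[C@H]1O[C@@H](n2cnc3c(NCc4cc(F)cc(F)c4)ncnc32)C(O)C1O` has no result in this assay: "not determined" (no result reported). Compound 1 thus sits at the limit of > 166000 nM in this assay, at which 2 of the 3 values shown sit, and no number places it relative to the others. Compound 4 `OC[C@H]1O[C@@H](n2cnc3c(NCc4cccc(O)c4O)ncnc32)[C@H](O)[C@@H]1O` differs from compound 1 by 2,3-dihydroxyphenyl in place of 2,4-dichlorophenyl on a saturated chain carbon bound to a nitrogen on an aromatic ring. Within the data shown here, both measured values in this assay are limits, and no step between measured compounds exists to set a direction. A step from compound 1 to compound 4 of a number no higher from compound 1 to compound 4 (the limit leaves the size open) is expected, meaning none beyond the scatter. Compound 4 is estimated at 166000 nM, with a range from 50000 nM to 500000 nM, and would most likely again be reported only as a limit.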

Compound 4, half-maximal inhibitory concentration: > 166000 nM
Compound 4 was reported as a limit; the forecaster's own chance of this, stated with the estimate: 85%; the middle value lies on the limit itself.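

In this assay compound 4 gives > 166000 nM, a limit. Among these compounds, with compound 1 also at a limit, no step between compound 1 and compound 4 can be read. As far as these compounds go, whether any benzyl group on the shared core gives a measurable value in this assay stays open.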